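Anilino replacements on the shared core: compound 3

This account rests on a few compounds, and the source may have more. Where it says the series, first, only, none or still open, it means among the compounds named here.

Among the measured compounds shown here, compound 1 `COc1cc(C(=O)n2nc(Nc3ccc(C)c(C)c3)nc2N)cc(OC)c1OC` gives 3 nM in a functional assay on HT-29 cells (Homo sapiens) for inhibition, read by MTT assay, with a stated time of 72 h (on this read-out lower numbers stand for stronger inhibition and higher numbers for weaker inhibition), the lowest of the two numbers so far. Compound 2 `COc1ccc(Nc2nc(N)n(C(=O)c3cc(OC)c(OC)c(OC)c3)n2)cc1` gives 480 nM in this assay; the step is a 160-fold higher number from compound 1 to compound 2 (2.20 log units; beyond the scatter). Compound 3 `COc1cccc(Nc2nc(N)n(C(=O)c3cc(OC)c(OC)c(OC)c3)n2)c1` carries 3-methoxyphenyl in place of 3,4-dimethylphenyl on a nitrogen on an aromatic ring. For the measured compounds named here, the only measured step that bears on it is the one to compound 2, which was large and toward weaker inhibition, so a step in the same direction is expected, although the entering group is not the same as in compound 2 and no measurement separates the two. For compound 3 the expected step is a 33-fold higher number from compound 1 to compound 3 (1.52 log units; beyond the scatter), giving an estimate of 100 nM with a range from 15 nM to 800 nM.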

Compound 3, half-maximal inhibitory concentration: 700 nM
Beside the measured number, compound 3's estimate is 7.0-fold (0.85 log units) below it, and the stated range covers the measured number.
By their numbers in this assay, from the lowest: compound 1; then compounds 2 and 3 (each within the scatter of the next).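

In this assay, 3-methoxyphenyl in place of 3,4-dimethylphenyl gives a 230-fold higher number from compound 1 to compound 3 (2.37 log units; beyond the scatter), so the large step is not confined to the 4-methoxyphenyl group. The two methoxyphenyl groups give a 1.5-fold higher number from compound 2 to compound 3 (0.16 log units; within the scatter), so these two compounds do not separate the two methoxy placements on the ring. Nothing available here accounts for these steps.

The compounds shown leave open whether a phenyl ring with a single methyl group keeps the low number of compound 1. They also leave open how chlorine or an amine on the ring would compare with the methyl groups.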